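From methoxy to trifluoromethyl: working notes on compound 3

This account rests on a few compounds, and the source may have more. Where it says the series, first, only, none or still open, it means among the compounds named here.

In a functional assay on L1210 cells (Mus musculus) for antiproliferative activity (on this read-out lower numbers stand for stronger inhibition and higher numbers for weaker inhibition), compound 1 (`COc1ccc(-c2cc(N)c(C(=O)c3cc(OC)c(OC)c(OC)c3)s2)cc1OC`) gives 40 nM and compound 2 (`COc1ccc(-c2cc(N)c(C(=O)c3cc(OC)c(OC)c(OC)c3)s2)cc1`) gives 45 nM. Among the compounds with values here, compound 2 therefore stands within the scatter of compound 1, the only other measured member of the series.

The next structure is compound 3 (`COc1cc(C(=O)c2sc(-c3ccc(C(F)(F)F)cc3)cc2N)cc(OC)c1OC`), which has trifluoromethyl in place of methoxy on an aromatic carbon, para to a large group, so that 4-methoxyphenyl becomes 4-(trifluoromethyl)phenyl: trifluoromethyl in place of methoxy on an aromatic carbon.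

Within the data shown here, only one measured step bears on this, and only indirectly. Hydrogen in place of methoxy on an aromatic carbon gave a 1.1-fold higher number from compound 1 to compound 2 (0.05 log units; within the scatter). Among the measured compounds shown here, that step leaves untouched the methoxy that departs now, so no measured compound lacks this group. A step beyond the scatter is nevertheless expected in this assay, towards a higher number and thus weaker inhibition. This expectation rests on the structural change alone, and the range is kept wide. The expected step is a 3.3-fold higher number from compound 2 to compound 3 (0.52 log units; beyond the scatter). For compound 3 the estimated value is 150 nM, with an expected range from 40 nM to 600 nM.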

Compound 3, half-maximal inhibitory concentration: 370 nM
The estimate for compound 3 lay 2.5-fold (0.39 log units) below the measured number; low and high end bracket the measured number.
By their numbers in this assay, from the lowest: compounds 1 and 2 (each within the scatter of the next); then compound 3.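

In this assay the 4-position of this phenyl ring proves sensitive to the group it carries: trifluoromethyl in place of methoxy gives an 8.2-fold higher number from compound 2 to compound 3 (0.91 log units; beyond the scatter), whereas the earlier loss of the other methoxy gave only a 1.1-fold higher number from compound 1 to compound 2 (0.05 log units; within the scatter). Set against the 3,4-dimethoxyphenyl of compound 1, the 4-(trifluoromethyl)phenyl of compound 3 gives a 9.3-fold higher number from compound 1 to compound 3 (0.97 log units; beyond the scatter), and since compound 1 and compound 2 lie within the scatter of each other, the exchange at this one position accounts for the separation of compound 3 from both. There is no supporting measurement at hand that would explain this weaker inhibition.

The compounds shown leave open whether the higher number follows from the departure of methoxy or from the arrival of trifluoromethyl, and a phenyl ring with plain hydrogen at this position would separate the two. From the compounds shown here alone, how far the position tolerates other groups also stays open, with a hydroxyl, a fluorine, a methyl, a nitrile or a dimethylamino group each able to show whether methoxy is special here or merely one of several acceptable groups.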